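Moving the chlorine: notes on compounds 1 to 4

The compounds below may be only part of what the source reports. "The series", "measured", "known", "first", "only" and "open" are said of these compounds alone.

Compound 1 `O=C(CCc1nnc(-c2ccccc2Cl)o1)c1ccccc1` carries a 2-chlorophenyl group on its five-membered ring; in a functional assay on the whole organism (strain Wistar) for inhibition, with Rattus norvegicus as the target, with stated times of 30 min and 3 h, at a dose of 20 mg/kg by the oral route (on this read-out higher numbers stand for more inhibition at the one dose given (going by the name of the read-out) and lower numbers for less inhibition), compound 1 gives 35.8%. Compound 2 `O=C(CCc1nnc(-c2ccc(Cl)cc2)o1)c1ccccc1` differs from it by 4-chlorophenyl in place of 2-chlorophenyl on an aromatic carbon, and in this assay compound 2 gives 81.5%, a step of a number 45.7 percentage points higher from compound 1 to compound 2 (beyond the scatter). Compound 3 `Cc1ccc(C(=O)CCc2nnc(-c3ccccc3Cl)o2)cc1` differs from compound 1 by methyl in place of hydrogen on an aromatic carbon; in this assay compound 3 gives 57.3%, a step of a number 21.5 percentage points higher from compound 1 to compound 3 (beyond the scatter). Compound 3 therefore stands between compound 1 and compound 2, with both gaps beyond the scatter.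

Compound 4 `Cc1ccc(C(=O)CCc2nnc(-c3ccc(Cl)cc3)o2)cc1` has not yet been measured. It differs from compound 3 by 4-chlorophenyl in place of 2-chlorophenyl on an aromatic carbon. This is the same change as from compound 1 to compound 2, now made on the core of compound 3, which carries the methyl group noted above; the place of the change is the same in both pairs, on an aromatic carbon of the five-membered aromatic ring with 2 nitrogen and 1 oxygen, next to the ring nitrogen and next to the ring oxygen.

A rise is expected for compound 4 because the matching step a number 45.7 percentage points higher from compound 1 to compound 2 (beyond the scatter) was large. Since compound 3 already gives 57.3%, a higher starting number than the earlier step had, the expected step is smaller than the earlier one, estimated at a number 30.7 percentage points higher from compound 3 to compound 4 (beyond the scatter). Compound 4 is thus expected to give 88%, most likely between 70% and 98%.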

Compound 4, a percentage reported as inhibition, in the whole organism at one dose (the size of the read-out at that dose, not a potency): 81.5%
Estimate against measurement, compound 4: 6.5 percentage points above; low and high end bracket the measured number.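

In this assay the change to 4-chlorophenyl in place of 2-chlorophenyl gives a number 24.2 percentage points higher from compound 3 to compound 4 (beyond the scatter), so its direction carries over to the core of compound 3, while its size does not: the same change on two cores in this assay, a number 45.7 percentage points higher (beyond the scatter) from compound 1 to compound 2 and a number 24.2 percentage points higher (beyond the scatter) from compound 3 to compound 4, 21.5 percentage points apart, beyond the scatter of two such steps. The methyl group in place of hydrogen does not read the same on the two cores either, giving no change at the digits printed from compound 2 to compound 4 (within the scatter), whereas it gave a clear rise on the core of compound 1: the same change on two cores in this assay, a number 21.5 percentage points higher (beyond the scatter) from compound 1 to compound 3 and no change at the digits printed (within the scatter) from compound 2 to compound 4, 21.5 percentage points apart, beyond the scatter of two such steps. The four compounds form a single set of paired changes on one read-out at one dose, so they do not show why the steps differ, whether the matching numbers of compound 2 and compound 4 mark a ceiling of the read-out at this dose, or whether the pattern extends to any other core.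

Open, from the compounds shown here alone, is whether an unsubstituted phenyl, a methoxyphenyl or a dimethylamino group in place of the 4-chlorophenyl would follow the same steps, and whether a carboxylic acid in place of the methyl would behave as the methyl does. It is also open whether a longer chain in place of the present link to the carbonyl would keep the same order among these changes.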